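Swapping a ring imide for an ethyl urea: solubility outlook

The source may hold more compounds than are shown below. What is called first, only, known or untested is meant among the compounds shown, and "the series" means these compounds.

Compound 1 `O=C1CCC(=O)N1C[C@H]1CN(c2ccc(-n3cc(-c4ccccn4)cn3)c(F)c2)C(=O)O1` sits in the middle of three compounds in a physicochemical assay for solubility, read by HPLC, with a stated time of 24 h (a lower number here means a less soluble compound, a higher number a more soluble compound), giving 45300 nM. Compound 3 `O=CNC[C@H]1CN(c2ccc(-n3cc(-c4ccccn4)cn3)c(F)c2)C(=O)O1` gives 217000 nM, and compound 2 `O=C1O[C@@H](CSc2cccs2)CN1c1ccc(-n2cc(-c3ccccn3)cn2)c(F)c1` gives 8500 nM. Compound 4 `CCNC(=O)NC[C@H]1CN(c2ccc(-n3cc(-c4ccccn4)cn3)c(F)c2)C(=O)O1` differs from compound 1 by (ethylcarbamoyl)amino in place of 2,5-dioxopyrrolidin-1-yl on a saturated chain carbon bound to a saturated ring carbon. The step that bears most on this is a 4.8-fold higher number from compound 1 to compound 3 (0.68 log units; beyond the scatter), where another small open-chain group carrying a hydrogen-bond donor replaced the same imide ring; the opposite move, a 5.3-fold lower number from compound 1 to compound 2 (0.73 log units; beyond the scatter), went the other way. Since compound 4 also trades the ring for an open chain with donors, a modest rise in this assay is expected, roughly a 2.6-fold higher number from compound 1 to compound 4 (0.42 log units; beyond the scatter). Compound 4 is therefore estimated at 120000 nM, with a range from 40000 nM to 350000 nM.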

Compound 4, solubility: 222000 nM
The estimate for compound 4 lay 1.9-fold (0.27 log units) below the measured number, within the range that was stated.
By their numbers in this assay, from the lowest: compound 2; then compound 1; then compounds 3 and 4 (each within the scatter of the next).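

Replacing 2,5-dioxopyrrolidin-1-yl with the open-chain (ethylcarbamoyl)amino group raises the reading in this assay (a 4.9-fold higher number from compound 1 to compound 4 (0.69 log units; beyond the scatter)), and replacing (thiophen-2-yl)sulfanyl with it has a larger effect (a 26-fold higher number from compound 2 to compound 4 (1.42 log units; beyond the scatter)). Ethylamino in place of hydrogen on a carbonyl carbon gives no separation (a 1.0-fold higher number from compound 3 to compound 4 (0.01 log units; within the scatter)), so the two open-chain groups cannot be told apart here. Nothing available explains these differences. Still open, as far as these compounds go, is how a plain amine, a carboxylic acid or a longer chain in place of the ethyl would read at this position.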